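Anilide versus propylamide in a cell cytotoxicity screen

The compounds below may be only part of what the source reports. "The series", "measured", "known", "first", "only" and "open" are said of these compounds alone.

Compound 1 `C=CC1=C(C(=O)Nc2ccccc2)C(c2ccc(OC)cc2)OC1` gives in a functional assay on SW480 cells (Homo sapiens) for cytotoxicity, read by MTT assay, with a stated time of 24 h (a lower number here means a stronger inhibitor, a higher number a weaker inhibitor), only a limit of the assay: > 100000 nM.
Compound 2 `C=CC1=C(C(=O)NCCC)C(c2ccc(OC)c(OC)c2)OC1` likewise gives only a limit: > 100000 nM.
Compound 3 `C=CC1=C(C(=O)NCCC)C(c2ccc(OC)cc2)OC1` likewise gives only a limit: > 100000 nM.

Compound 2 therefore stands where its two neighbours stand, at the assay limit, with no number attached. The compound still to be tested is compound 4 `C=CC1=C(C(=O)Nc2ccccc2)C(c2ccc(OC)c(OC)c2)OC1`, which differs from compound 2 by phenyl in place of propyl on an amide-type nitrogen. Among the compounds with values here, two measured steps touch this change. The step that the two limits leave unreadable from compound 1 to compound 3 is the same exchange run backwards on the core with one methoxy group, but its size cannot be read because of the limit of > 100000 nM in this assay, at which 3 of the 3 values shown sit. The step that the two limits leave unreadable from compound 2 to compound 3 is unreadable for the same reason. The measured steps thus give neither a size nor a direction, and the expectation rests only on all three compounds sitting at the limit. The step that the limit leaves unreadable from compound 2 to compound 4 is expected to be none beyond the scatter. Compound 4 is estimated at 200000 nM, with a range from 60000 nM to 1000000 nM, most probably reported once more as a limit.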

Compound 4, half-maximal inhibitory concentration: 45100 nM
Beside the measured number, compound 4's estimate is 4.4-fold (0.65 log units) above it; measured number below the stated range.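

In this assay, phenyl in place of propyl on the amide-type nitrogen gives an at least 2.2-fold lower number from compound 2 to compound 4 (0.34 log units; beyond the scatter), and methoxy in place of hydrogen on an aromatic carbon gives an at least 2.2-fold lower number from compound 1 to compound 4 (0.34 log units; beyond the scatter). Among the compounds shown, only compound 4 combines the phenyl with the added methoxy, and it alone gives a number rather than a limit, while compound 1 has only the phenyl and compound 2 only the added methoxy. The earlier steps cannot be read because all three earlier values are the same limit: the limit of > 100000 nM in this assay, at which 3 of the 4 values shown sit.

Going by these compounds, both new steps start from a limit, so their full size remains open. Also open, on these data alone, is whether a benzyl group or a longer chain on the amide nitrogen, or a chlorine atom in place of the added methoxy, would give a number in this assay.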